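Removing one methoxy from compound 2: expectation for compound 3

A few compounds are considered here, and "the series" means these few. Any claim that something is new, unique, unknown or untested is made for them only; others in the source may bear on it.

Measured so far:
compound 1, `COc1cc(-c2cc(/C=C/C(=O)c3ccc(Cl)c(Cl)c3)[nH]n2)cc(OC)c1OC`, 4380 nM
compound 2, `COc1ccc(C(=O)/C=C/c2cc(-c3cc(OC)c(OC)c(OC)c3)n[nH]2)cc1OC`, 2110 nM

Going by the values given here, in a functional assay on MOLT-4 cells (Homo sapiens) for inhibition, read by sulforhodamine B assay, with a stated time of 48 h (a higher number here means a weaker inhibitor of growth, a lower number a stronger inhibitor of growth), compound 2 gives 2110 nM, the lowest of the two numbers so far; compound 1 gives 4380 nM. Among the compounds with values here, the one measured step, a 2.1-fold lower number from compound 1 to compound 2 (0.32 log units; beyond the scatter), concerns the ring attached to the carbonyl carbon and counts as modest.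

Compound 3, `COc1ccc(C(=O)/C=C/c2cc(-c3cc(OC)c(OC)c(OC)c3)n[nH]2)cc1`, is not yet measured. It differs from compound 2 by hydrogen in place of methoxy on an aromatic carbon. Within the data shown here, no measured step bears directly on this change: both measured compounds carry two substituents on the ring at the carbonyl carbon, and the only step swaps one pair of substituents for another rather than removing one. That step stays modest, which suggests this ring tolerates change without large movement of the number. Among the measured compounds shown here, with no direct precedent, the loss of a single methoxy is expected to give at most a small step, likely toward a somewhat higher number, and not clearly beyond the scatter.

Compound 3 is therefore expected near 3000 nM, with a range from 1200 nM to 7500 nM. This corresponds to an estimated step of a 1.4-fold higher number from compound 2 to compound 3 (0.15 log units; within the scatter).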

Compound 3, concentration for 50% growth inhibition: 2670 nM
For compound 3 the middle estimate is 1.1-fold (0.05 log units) above the measured one; measured number inside the range.
By their numbers in this assay, from the lowest: compounds 2, 3 and 1 (each within the scatter of the next, the first and the last beyond it).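

In this assay, going by these compounds alone, replacing the methoxy ortho to a methoxy group, which turns 3,4-dimethoxyphenyl into 4-methoxyphenyl, gives a 1.3-fold higher number from compound 2 to compound 3 (0.10 log units; within the scatter), the first direct reading of a single group's removal from the ring on the carbonyl carbon; this methoxy is therefore not needed to keep the number within the scatter of compound 2. Within the data shown here, replacing 3,4-dichlorophenyl with 4-methoxyphenyl gives a 1.6-fold lower number from compound 1 to compound 3 (0.21 log units; within the scatter), whereas only the step to the 3,4-dimethoxyphenyl compound, a 2.1-fold lower number from compound 1 to compound 2 (0.32 log units; beyond the scatter), lies beyond the scatter, so the separation from the dichloro compound rests on that single pair. No measurement available here accounts for these numbers.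

The compounds shown leave open whether the remaining methoxy of compound 3 matters, since no compound here has a hydrogen, a hydroxy group or an amine in its place on this ring. Going by these compounds, the rest of the core is also the same in compounds 1, 2 and 3, so it is unknown whether the small step from losing this methoxy would hold with a different group on the far side of the core.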